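This account rests on a few compounds, and the source may have more. Where it says the series, first, only, none or still open, it means among the compounds named here.

Three compounds already have numbers in a physicochemical assay for lipophilicity; on this read-out lower numbers stand for lower lipophilicity and higher numbers for higher lipophilicity. Among the measured compounds shown here, compound 1 `Cc1ccc(NC(=O)CC(CCN(C)C)c2nnc(CCCC(C)C)n2C2CC2)c(C)c1` gives 3.3, and compound 2 `CC(=O)NCCC(CC(=O)Nc1ccc(C)cc1C)c1nnc(CCCC(C)C)n1C1CC1` gives 3.5; the single change between them, a number 0.20 log units higher from compound 1 to compound 2 (within the scatter), stays within the scatter. Compound 3 `Cc1ccc(NC(=O)C[C@H](CCC(=O)O)c2noc(-c3ccc(CC(C)C)cc3)c2C2CC2)c(Cl)c1` gives 4.8, the highest of the three: compound 2 lies nearest and compound 1 furthest, both beyond the scatter.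

Compound 4 `Cc1ccc(NC(=O)C[C@H](CCC(=O)O)c2noc(-c3cc(C(F)(F)CC(C)C)on3)c2C2CC2)c(Cl)c1` has not yet been measured. It differs from compound 3 in one place: 5-(1,1-difluoro-3-methylbutyl)-1,2-oxazol-3-yl in place of 4-isobutylphenyl on an aromatic carbon. For the measured compounds named here, no measured step follows a change of this kind; the only measured step concerns a group on a saturated chain and says nothing about exchanging one aromatic group for another. The expectation therefore rests on the counted difference alone, in which a group with hydrogen-bond acceptors enters where the leaving group had none. A moderate step downward in this assay is expected, a number 0.60 log units lower from compound 3 to compound 4 (beyond the scatter), with wide uncertainty. Compound 4 is expected to come out at 4.2, between 3.5 and 4.9.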

Compound 4, distribution coefficient: 4.4
For compound 4 the middle estimate is 0.20 log units below the measured one; the range from low to high includes it.
By their numbers in this assay, from the lowest: compounds 1 and 2 (each within the scatter of the next); then compound 4; then compound 3.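

Among the compounds shown here, exchanging one aromatic group for another at this position, on an aromatic carbon of the five-membered aromatic ring with 1 nitrogen and 1 oxygen, gives a number 0.40 log units lower from compound 3 to compound 4 (beyond the scatter) in this assay, a change no earlier step could show. The drop is modest, and it comes with an entering group that has more heavy atoms than the leaving one and carries hydrogen-bond acceptors where 4-isobutylphenyl had none. No supporting measurement bears on why the number falls.

The ring and the side chain change together here, so the compounds shown do not separate what each part contributes. A 5-isobutyl-1,2-oxazol-3-yl group, the same ring with a chain free of fluorine, would help to separate the two in this assay.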